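The compounds below may be only part of what the source reports. "The series", "measured", "known", "first", "only" and "open" are said of these compounds alone.

Measured compounds:
- compound 1: `Cc1nc(S(C)(=O)=O)ccc1Oc1ncnc(OC2CCN(C(=O)OC3(C(F)(F)F)COC3)CC2)c1F` — in a functional assay on isolated protein for inhibition of Glucose-dependent insulinotropic receptor (Rattus norvegicus), read by HTRF and cAMP accumulation (on this read-out lower numbers stand for smaller maximal responses and higher numbers for larger maximal responses), compound 1 gives 84%
- compound 2: `Cc1nc(S(C)(=O)=O)ccc1Oc1ncnc(OC2CCN(C(=O)C(C)(F)F)CC2)c1F` — in this assay compound 2 gives 87%

Compound 2 stands alongside compound 1 in this assay; the step of a number 3 percentage points higher from compound 1 to compound 2 (within the scatter) is within the scatter, so the two numbers cannot be told apart and neither compound can be called the more or less efficacious.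

Compound 3 is `Cc1nc(S(C)(=O)=O)ccc1Oc1ncnc(OC2CCN(C(=O)C(C)(C)F)CC2)c1F`. It differs from compound 2 in the group on the carbonyl carbon: methyl in place of fluoro on a saturated chain carbon bound to a carbonyl carbon, a fluorine atom and a saturated chain carbon.

Going by the values given here, only one measured step bears on this position. Exchanging the whole group on the carbonyl carbon gave a number 3 percentage points higher from compound 1 to compound 2 (within the scatter), which is within the scatter. Among the compounds with values here, that exchange is larger than the one from compound 2 to compound 3, yet the largest response did not move beyond the scatter. Within the data shown here, no measured pair tests fluoro against methyl on this saturated chain carbon, so no direction is indicated by the data.

Compound 3 is therefore expected to give a largest response close to that of compound 2, with the step of a number 2 percentage points lower from compound 2 to compound 3 (within the scatter) expected to lie within the scatter. The estimate for compound 3 in this assay is 85%, with a range from 72% to 96%.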

Compound 3, largest response reached (reported as efficacy), in percent of the reference or control that the assay uses: 74%
For compound 3 the middle estimate is 11 percentage points above the measured one, within the range that was stated.
By their numbers in this assay, from the lowest: compounds 3, 1 and 2 (each within the scatter of the next, the first and the last beyond it).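

In this assay, methyl in place of fluoro on a saturated chain carbon bound to a carbonyl carbon gives a number 13 percentage points lower from compound 2 to compound 3 (beyond the scatter), so an exchange of one atom for one atom moves the largest response beyond the scatter, whereas replacing the whole group on the carbonyl carbon gave only a number 3 percentage points higher from compound 1 to compound 2 (within the scatter). The position is therefore sensitive to the change from 1,1-difluoroethyl to 1-fluoro-1-methylethyl, although the reach of that sensitivity is limited: 1-fluoro-1-methylethyl in place of (3-(trifluoromethyl)oxetan-3-yl)oxy gives a number 10 percentage points lower from compound 1 to compound 3 (within the scatter), leaving compound 1 and compound 3 inseparable, and only compound 2 and compound 3 stand apart. No supporting measurement bears on this result.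

On these data alone, whether the response drops further with tert-butyl on the carbonyl carbon, where the remaining fluorine also gives way to methyl, or whether a longer chain such as 1,1-difluoropropyl stays level with compound 2, remains open. The compounds shown also leave open whether a cyclopropyl group on the carbonyl carbon would behave like the open-chain groups in this assay.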